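Aryl-bearing amide chain returns in place of cyclohexylethyl

The source may report more compounds than this note shows. Statements on the series, on what has been measured and on what is new or still open speak of the compounds shown alone.

Compound 2 `CC(C)C[C@H](N)c1cc(C(F)(F)F)ccc1N1CCN(C(=O)CCC2CCCCC2)CC1` gives 5700 nM in an assay on HEK293 cells for displacement of a labelled ligand from Melanocortin receptor 4 (Homo sapiens) (on this read-out higher numbers stand for weaker inhibition and lower numbers for stronger inhibition), the highest of the two numbers at hand; compound 1 `COc1cc(CC(C)C(=O)N2CCN(c3ccc(C(F)(F)F)cc3[C@@H](N)CC(C)C)CC2)ccc1Cl` gives 230 nM in this assay. For the measured compounds named here, the single measured step, a 25-fold higher number from compound 1 to compound 2 (1.39 log units; beyond the scatter), put 2-cyclohexylethyl in place of 1-(4-chloro-3-methoxybenzyl)ethyl on a carbonyl carbon. Compound 3 `COc1ccc(CC(C)C(=O)N2CCN(c3ccc(C(F)(F)F)cc3[C@@H](N)CC(C)C)CC2)cc1F` reverses that type of change: 1-(3-fluoro-4-methoxybenzyl)ethyl in place of 2-cyclohexylethyl on a carbonyl carbon. Since the aryl-bearing compound 1 sits at 230 nM, a large drop in this assay is expected, broadly undoing the earlier step. Compound 3 is therefore estimated at 300 nM, range 100 nM to 1000 nM, an expected step of a 19-fold lower number from compound 2 to compound 3 (1.28 log units; beyond the scatter).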

Compound 3, inhibition constant: 200 nM
Compound 3: the middle estimate sits 1.5-fold (0.18 log units) above what was measured; measured number inside the range.
By their numbers in this assay, from the lowest: compounds 3 and 1 (each within the scatter of the next); then compound 2.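

In this assay, the large step is regained with a second substituted aryl chain: a 29-fold lower number from compound 2 to compound 3 (1.45 log units; beyond the scatter) came with 1-(3-fluoro-4-methoxybenzyl)ethyl on the carbonyl carbon. Exchanging 4-chloro-3-methoxyphenyl for 3-fluoro-4-methoxyphenyl gives a 1.2-fold lower number from compound 1 to compound 3 (0.06 log units; within the scatter) and so leaves these two ring patterns unseparated. No evidence on the reason for either step is at hand.

Compound 2 and compound 3 differ in both ring type and chain branching, so these two changes remain unseparated. Also open, on these data alone, is whether an unsubstituted phenyl, or a ring bearing an amine or a carboxylic acid, would hold this level.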